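Swapping the benzylidene aryl on a pyridyl-triazole hydrazone

The source may report more compounds than this note shows. Statements on the series, on what has been measured and on what is new or still open speak of the compounds shown alone.

Compound 1 `O=C(CSc1nnc(-c2ccncc2)n1-c1ccccc1)N/N=C/c1ccccc1`: 23600 nM
Compound 2 `O=C(CSc1nnc(-c2ccncc2)n1-c1ccccc1)N/N=C/c1ccc(Cl)cc1`: 9930 nM
Compound 3 `O=C(CSc1nnc(-c2ccncc2)n1-c1ccccc1)N/N=C/c1ccccc1F`: 22400 nM

Three hydrazones sharing one core have been measured in a functional assay on MCF7 cells (Homo sapiens) for inhibition, read by MTT assay, with a stated time of 48 h; on this read-out higher numbers stand for weaker inhibition and lower numbers for stronger inhibition. Compound 3 gives the second highest of the three numbers; its nearest neighbour is compound 1, at a gap that stays within the scatter, while compound 2 sits clearly below it. Compound 4 `O=C(CSc1nnc(-c2ccncc2)n1-c1ccccc1)N/N=C/c1cc(Br)ccc1O` carries 5-bromo-2-hydroxyphenyl in place of 2-fluorophenyl on a carbon with a double bond to nitrogen.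

For the measured compounds named here, two measured steps bear on this change. The chloro on the aromatic ring gave a 2.4-fold lower number from compound 1 to compound 2 (0.38 log units; beyond the scatter), while the fluoro gave a 1.1-fold lower number from compound 1 to compound 3 (0.02 log units; within the scatter), and between the two aryl groups the difference was a 2.3-fold higher number from compound 2 to compound 3 (0.35 log units; beyond the scatter). A bromine on the ring is the nearer relative of the chloro case, so a modest lowering of the number for compound 4 is expected; the hydroxyl has no precedent among these three and widens the uncertainty. Compound 4 is therefore estimated at 10000 nM, within a range from 4000 nM to 25000 nM. The expected step is a 2.2-fold lower number from compound 3 to compound 4 (0.35 log units; beyond the scatter), a modest move toward stronger inhibition in this assay, because the chloro analogue showed a 2.4-fold lower number from compound 1 to compound 2 (0.38 log units; beyond the scatter).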

Compound 4, half-maximal inhibitory concentration: 6460 nM
The estimate for compound 4 lay 1.5-fold (0.19 log units) above the measured number; low and high end bracket the measured number.
By their numbers in this assay, from the lowest: compounds 4 and 2 (each within the scatter of the next); then compounds 3 and 1 (each within the scatter of the next).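

In this assay the 5-bromo-2-hydroxyphenyl group on the carbon with a double bond to nitrogen brings a hydrogen-bond donor and acceptor that 2-fluorophenyl lacks, and the read-out shows a 3.5-fold lower number from compound 3 to compound 4 (0.54 log units; beyond the scatter) together with a 3.7-fold lower number from compound 1 to compound 4 (0.56 log units; beyond the scatter) against the plain phenyl. Measured against 4-chlorophenyl the step is a 1.5-fold lower number from compound 2 to compound 4 (0.19 log units; within the scatter) and so these two compounds stand level. Until now only the chloro had moved the number beyond the scatter from phenyl; this position now accepts a second, different aryl group at that same level, one that carries a hydroxyl, while compound 1 and compound 3 stay together at the weaker end of the four.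

Compound 4 differs from the plain phenyl of compound 1 by two ring substituents at once, so what the bromine and the hydroxyl each contribute stays unresolved, as does the outcome with an amine or a carboxylic acid on the same ring. Nothing shown here gives a measured reason for the shift in the number.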